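This account rests on a few compounds, and the source may have more. Where it says the series, first, only, none or still open, it means among the compounds named here.

Measured in a functional assay on Jurkat cells (Homo sapiens) for antiproliferative activity, read by MTT assay, with a stated time of 48 h; a lower number here means a stronger inhibitor, a higher number a weaker inhibitor:
- compound 1 `O=C(CCCCCn1cc(Nc2ncc(Cl)c(Nc3cccc(Cl)c3)n2)cn1)NO`: 50 nM
- compound 2 `CNc1nc(Nc2cnn(CCCCCCC(=O)NO)c2)ncc1Cl`: 70 nM
- compound 3 `O=C(CCCCCCn1cc(Nc2ncc(Cl)c(Nc3ccc(F)cc3)n2)cn1)NO`: 120 nM

Compound 3, at 120 nM, lies above compound 1, at 50 nM, beyond the scatter, and level with compound 2. Next is compound 4 `O=C(CCCCCn1cc(Nc2ncc(Cl)c(Nc3ccc(F)cc3)n2)cn1)NO`, which shortens the chain of compound 3: hydroxycarbamoyl in place of (hydroxycarbamoyl)methyl on a saturated chain carbon, five bonds along the chain from an aromatic nitrogen. Going by the values given here, no measured step covers this change. Among the compounds with values here, the one step available, a 1.7-fold higher number from compound 2 to compound 3 (0.23 log units; within the scatter), lies elsewhere in the molecule and stays within the scatter. Compound 1 carries the chain of compound 4 but differs elsewhere, so its value offers only a loose hint towards a lower number in this assay. The expected result is a small move, not clearly beyond the scatter: a 1.5-fold lower number from compound 3 to compound 4 (0.18 log units; within the scatter). For compound 4 the estimated value is 80 nM, with an expected range of 30 nM to 220 nM.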

Compound 4, half-maximal inhibitory concentration: 60 nM
Compound 4: middle estimate off by 1.3-fold (0.12 log units), on the high side; the range from low to high includes it.
By their numbers in this assay, from the lowest: compounds 1, 4, 2 and 3 (each within the scatter of the next, the first and the last beyond it).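

In this assay, going by these compounds alone, the first measured change at this place, five bonds along the chain from an aromatic nitrogen, is hydroxycarbamoyl in place of (hydroxycarbamoyl)methyl (a 2.0-fold lower number from compound 3 to compound 4 (0.30 log units; within the scatter)), so these two chain lengths are not separated. With the shorter chain held fixed, 4-fluorophenyl in place of 3-chlorophenyl (a 1.2-fold higher number from compound 1 to compound 4 (0.08 log units; within the scatter)) is not separated either. No measurement on hand accounts for either step.

Open, from the compounds shown here alone, is how a longer chain would read in this assay. Also open, going by these compounds, is a carboxylic acid in place of hydroxycarbamoyl.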